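The compounds below may be only part of what the source reports. "The series", "measured", "known", "first", "only" and "open" are said of these compounds alone.

Measured so far:
compound 1 `COc1cc(-c2nn(-c3cccc(NC(=O)Nc4cc(C(F)(F)F)cc(C(F)(F)F)c4)c3)cc2-c2ccncc2)ccc1Cl` — 826 nM in a functional assay on IGROV-1 cells (Homo sapiens) for inhibition, read by sulforhodamine B assay, with a stated time of 48 h; a lower number here means a stronger inhibitor of growth, a higher number a weaker inhibitor of growth
compound 2 `COc1cc(-c2nn(-c3cccc(NC(=O)Nc4cccc(C(F)(F)F)c4)c3)cc2-c2ccncc2)ccc1Cl` — 1060 nM in this assay

Compound 2 gives the highest of the two numbers in this assay; its nearest neighbour is compound 1, and a 1.3-fold higher number from compound 1 to compound 2 (0.11 log units; within the scatter) is within the scatter, so the two stand together rather than in an order.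

Compound 3 `COc1cc(-c2nn(-c3cccc(NC(=O)c4ccccc4)c3)cc2-c2ccncc2)ccc1Cl` is not yet measured. It differs from compound 2 by phenyl in place of (3-(trifluoromethyl)phenyl)amino on a carbonyl carbon. Among the compounds with values here, the one measured step, a 1.3-fold higher number from compound 1 to compound 2 (0.11 log units; within the scatter), concerns a trifluoromethyl on the aromatic ring and says nothing about exchanging an aryl-amino group for phenyl on the carbonyl carbon. Within the data shown here, no measured step bears on the change, and compound 1 and compound 2 give no guidance on it. With this in mind, a moderate weakening is taken as the working expectation, with a wide range either way. Compound 3 is estimated at 2200 nM (range 700 nM to 7000 nM), an expected step of a 2.1-fold higher number from compound 2 to compound 3 (0.32 log units; beyond the scatter).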

Compound 3, concentration for 50% growth inhibition: 534 nM
Compound 3: middle estimate off by 4.1-fold (0.61 log units), on the high side, outside the stated range (below it).
By their numbers in this assay, from the lowest: compounds 3, 1 and 2 (each within the scatter of the next).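

In this assay, phenyl in place of (3-(trifluoromethyl)phenyl)amino on the carbonyl carbon gives a 2.0-fold lower number from compound 2 to compound 3 (0.30 log units; within the scatter), so this position tolerates a change larger than the trifluoromethyl exchange seen earlier. The entering group has fewer heavy atoms and no hydrogen-bond donor, yet the values stand together, so neither the amino link nor the trifluoromethyl is needed here for growth inhibition in this range. No measurement at hand accounts for this result.

The compounds shown do not separate the amino link from the trifluoromethyl, as the two leave together in this one change. Also open, from the compounds shown here alone, is whether the number holds with methyl, cyclohexyl or morpholine on the carbonyl carbon, or with a nitrile or a carboxylic acid on the entering phenyl.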